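This account rests on a few compounds, and the source may have more. Where it says the series, first, only, none or still open, it means among the compounds named here.

In an assay on HEK293 cells for positive allosteric modulation of metabotropic glutamate receptor 2 (Rattus norvegicus), read by thallium flux, with a stated time of 2.5 min (a higher number here means a larger maximal response, a lower number a smaller maximal response), compound 2 `Cc1c(OCCCCOc2ccc(C(=O)O)cc2F)ccc(C(=O)CC(C)C)c1O` gives 85% and sits alongside compound 1 `Cc1c(OCCCCOc2ccccc2C(=O)O)ccc(C(=O)CC(C)C)c1O`, which gives 92.4%, the two numbers lying within the scatter of each other, as the step of a number 7.4 percentage points lower from compound 1 to compound 2 (within the scatter) shows. Compound 3 `Cc1c(OCCCCOc2ccc(C(=O)O)cc2Cl)ccc(C(=O)CC(C)C)c1O` differs from compound 2 by chloro in place of fluoro on an aromatic carbon. Among the measured compounds shown here, no measured step swaps one halogen for another; the only step known, a number 7.4 percentage points lower from compound 1 to compound 2 (within the scatter), exchanges one carboxyphenyl group for another and stays within the scatter, so nothing beyond the scatter is expected here either. Compound 3 is therefore estimated to give about 85%, between 70% and 98%. The expected step is no change at the digits printed from compound 2 to compound 3 (within the scatter).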

Compound 3, largest response reached (reported as percent of maximum), in percent of the reference or control that the assay uses: 99.5%
For compound 3 the middle estimate is 14.5 percentage points below the measured one, and the stated range ends below it.
By their numbers in this assay, from the lowest: compounds 2, 1 and 3 (each within the scatter of the next, the first and the last beyond it).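

Among the compounds shown here, this is the first step to lie beyond the scatter: in this assay, the halogen on the aromatic carbon ortho to a large group matters, with chloro in place of fluoro giving a number 14.5 percentage points higher from compound 2 to compound 3 (beyond the scatter) on this one-atom change. Yet the step of a number 7.1 percentage points higher from compound 1 to compound 3 (within the scatter) stays within the scatter, so 4-carboxy-2-chlorophenyl and 2-carboxyphenyl cannot be told apart here. Nothing available explains the halogen step.

Open, going by these compounds, is whether bromo or methyl at this place would follow chloro or fluoro, and how a plain hydrogen there would compare.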